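The compounds below may be only part of what the source reports. "The series", "measured", "known", "first", "only" and "open" are said of these compounds alone.

Compound 2 `COc1cc2c(Oc3ccc(NC(=O)c4cn(-c5c(C)cccc5C)nn4)cc3F)ccnc2cc1OCCCN1CCC(C)CC1` is the weaker of two compounds measured in a functional assay on HT-29 cells (Homo sapiens) for cytotoxicity, read by MTT assay, with a stated time of 72 h (on this read-out higher numbers stand for weaker inhibition and lower numbers for stronger inhibition), where compound 2 gives 2450 nM. For the measured compounds named here, its nearest neighbour, compound 1 `COc1cc2c(Oc3ccc(NC(=O)c4cn(-c5ccccc5F)nn4)cc3F)ccnc2cc1OCCCN1CCC(C)CC1`, gives 210 nM, and the shift a 12-fold higher number from compound 1 to compound 2 (1.07 log units; beyond the scatter) is the only measured step. Compound 3 `COc1cc2c(Oc3ccc(NC(=O)c4cn(-c5ccc(F)c(F)c5)nn4)cc3F)ccnc2cc1OCCCN1CCC(C)CC1` differs from compound 2 by 3,4-difluorophenyl in place of 2,6-dimethylphenyl on an aromatic nitrogen, on the same aromatic nitrogen. Since compound 1, which carries a fluorinated ring at that position, gives 210 nM, a return toward stronger inhibition is expected for compound 3, with a value near 350 nM and a range from 100 nM to 1200 nM. The expected step is therefore a 7.0-fold lower number from compound 2 to compound 3 (0.85 log units; beyond the scatter).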

Compound 3, half-maximal inhibitory concentration: 810 nM
Compound 3: middle estimate off by 2.3-fold (0.36 log units), on the low side, within the range that was stated.
By their numbers in this assay, from the lowest: compound 1; then compound 3; then compound 2.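

Putting 3,4-difluorophenyl in place of 2,6-dimethylphenyl on the aromatic nitrogen gives a 3.0-fold lower number from compound 2 to compound 3 (0.48 log units; beyond the scatter) and so closes only part of the gap to compound 1. Fluorine on this ring is not enough on its own to match compound 1: a 3.9-fold higher number from compound 1 to compound 3 (0.59 log units; beyond the scatter) separates the two fluorinated rings, so which fluorinated ring sits here matters. Nothing available explains these differences. The compounds shown leave open how a plain phenyl, or a phenyl bearing an amine or a carboxylic acid, would compare with compound 1.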